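The compounds below may be only part of what the source reports. "The series", "measured", "known", "first", "only" and "open" are said of these compounds alone.

Series notes. In a functional assay on NCI-H460 cells (Homo sapiens) for antiproliferative activity, read by CCK-8 assay, with a stated time of 72 h, tested at 2 uM (on this read-out higher numbers stand for a stronger effect at the one concentration tested and lower numbers for a weaker effect), compound 1 `Nc1ccccc1NC(=O)c1ccc(CNc2nc(Cl)nc3c2ncn3Cc2ccccc2)cc1` gives 43.8%. Compound 2 `Nc1ccccc1NC(=O)c1ccc(COCNc2nc(Nc3ccc(-c4ccccc4)cc3)c3ncn(C4CCCC4)c3n2)cc1` gives 33.5% in this assay, the second highest of the three numbers recorded so far; its nearest neighbour is compound 1, whose reading is higher by a margin beyond the scatter, and its furthest is compound 3 `Nc1ccccc1NC(=O)/C=C/c1ccc(Cn2cnc3c(Nc4cccc(OC(F)(F)F)c4)nc(Cl)nc32)cc1`, which in this assay gives 2.1%, a reading well below compound 2 and beyond the scatter. For the measured compounds named here, no pair of measured compounds differs in a single place, so no measured step of one change is available as a guide. Compound 4 `Nc1ccccc1NC(=O)c1ccc(COCNc2nc(Nc3cccc(Cl)c3)c3ncn(C4CCCC4)c3n2)cc1` is the next compound of the series, and it differs from compound 2 by 3-chlorophenyl in place of 4-phenylphenyl on a nitrogen on an aromatic ring. With no measured step of this kind in the series, the step is expected to be modest, a number 5.5 percentage points lower from compound 2 to compound 4 (within the scatter), pointing downward but staying within the scatter. Compound 4 is therefore expected to give 28% in this assay, with a range from 12% to 46%.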

Compound 4, a percentage reported as inhibition, at one concentration (the size of the read-out at that concentration, not a potency): 36.1%
Compound 4: the middle estimate sits 8.1 percentage points below what was measured; the range from low to high includes it.
By their numbers in this assay, from the lowest: compound 3; then compounds 2, 4 and 1 (each within the scatter of the next, the first and the last beyond it).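

In this assay, for the compounds shown here, 3-chlorophenyl in place of 4-phenylphenyl on a nitrogen on an aromatic ring gives a number 2.6 percentage points higher from compound 2 to compound 4 (within the scatter), the first step of a single change. At this position, the two readings cannot be told apart, even though the second six-membered aromatic ring leaves and a chlorine enters, so for this pair the read-out at the one concentration tested does not depend on that ring. No measurement bears on why the two readings match.

Still open, going by these compounds, is whether this holds for groups other than these two aromatic ones, such as plain phenyl, cyclohexyl or a phenyl ring carrying a carboxylic acid or an amine. Since one pair defines this position, a single-concentration reading also leaves open whether potency matches across the pair.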